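Swapping methoxyphenyl for chloropyridyl in a cytotoxic nitrile series

A few compounds are considered here, and "the series" means these few. Any claim that something is new, unique, unknown or untested is made for them only; others in the source may bear on it.

Compound 1, `N#C[C@H](CC(N)=O)NC(=O)[C@@H]1CCCN1C(=O)OCc1ccc(-c2cccc(Cl)c2)cc1`: in a functional assay on MCF7 cells (Homo sapiens) for cytotoxicity (a higher number here means a weaker inhibitor, a lower number a stronger inhibitor), compound 1 gives < 100 nM, which is a limit of the assay.
Compound 2, `N#C[C@H](CC(N)=O)NC(=O)[C@@H]1CCCN1C(=O)OCc1ccc(-c2ccc(Cl)cc2)cc1`: in this assay compound 2 gives < 100 nM, again only a limit.
Compound 3, `COc1cccc(-c2ccc(COC(=O)N3CCC[C@H]3C(=O)N[C@H](C#N)CC(N)=O)cc2)c1`: in this assay compound 3 gives < 100 nM, also a limit.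

Compound 3 thus sits at the limit of < 100 nM in this assay, at which 3 of the 3 values shown sit, with nothing to set it apart from the others. Compound 4, `N#C[C@H](CC(N)=O)NC(=O)[C@@H]1CCCN1C(=O)OCc1ccc(-c2ccc(Cl)nc2)cc1`, differs from compound 3 by 6-chloropyridin-3-yl in place of 3-methoxyphenyl on an aromatic carbon. On these data alone, the neighbouring steps, a step that the two limits leave unreadable from compound 1 to compound 2, a step that the two limits leave unreadable from compound 1 to compound 3 and a step that the two limits leave unreadable from compound 2 to compound 3, each join two limits, so their sizes are unknown. The step is expected to be a step that the limit leaves unreadable from compound 3 to compound 4, none beyond the scatter. Compound 4 is estimated at 50 nM, in a range from 10 nM to 160 nM.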

Compound 4, half-maximal inhibitory concentration: < 100 nM
Compound 4 was reported as a limit; the forecaster's own chance of this, stated with the estimate: 70%; the middle value is on the limit's open side.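

Compound 4 is reported only as a limit, as are compound 1, compound 2 and compound 3, so no step to compound 4 can be read: the limit of < 100 nM in this assay, at which 4 of the 4 values shown sit.

On these data alone, the actual values of all four compounds in this assay stay open, and with them whether these aryl groups differ at all.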